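The source may hold more compounds than are shown below. What is called first, only, known or untested is meant among the compounds shown, and "the series" means these compounds.

In a functional assay on SK-BR-3 cells (Homo sapiens) for cytotoxicity, read by MTT assay, with a stated time of 72 h (a higher number here means a weaker inhibitor, a lower number a stronger inhibitor), compound 2 `N[C@H]1CC[C@H](Nc2c(C(=O)NCc3ccc(Cl)cc3Cl)nc(Br)c3cccnc23)CC1` gives 6000 nM and compound 3 `N[C@H]1CC[C@H](Nc2c(C(=O)NCc3ccc(Cl)cc3)nc(Br)c3cccnc23)CC1` gives 2000 nM, the lower of the two numbers. For compound 1 `N[C@H]1CC[C@H](Nc2c(C(=O)NCc3ccc(Oc4ccccc4)cc3)nc(Br)c3cccnc23)CC1` the result is "not determined" (no result reported). Compound 4 `N[C@H]1CC[C@H](Nc2c(C(=O)Nc3ccccc3)nc(Br)c3cccnc23)CC1` departs from compound 3 with phenyl in place of 4-chlorobenzyl on an amide-type nitrogen. For the measured compounds named here, only one measured step bears on this, and only loosely: a 3.0-fold lower number from compound 2 to compound 3 (0.48 log units; beyond the scatter), a modest change that removes a chloro on an aromatic carbon. Here the whole 4-chlorobenzyl leaves, and nothing measured tests phenyl on this nitrogen, so no direction is supported. The expected step is a 1.3-fold higher number from compound 3 to compound 4 (0.10 log units; within the scatter), which is not expected to exceed the scatter. For compound 4 the estimate is 2500 nM, with an expected range of 800 nM to 9000 nM.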

Compound 4, half-maximal inhibitory concentration: 2000 nM
Estimate against measurement, compound 4: 1.3-fold (0.10 log units) above, and the stated range covers the measured number.
By their numbers in this assay, from the lowest: compounds 3 and 4 (each within the scatter of the next); then compound 2.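

In this assay, phenyl in place of 4-chlorobenzyl on the amide-type nitrogen gives no change at the digits printed from compound 3 to compound 4 (within the scatter), so the benzyl carbon and the chloro can both go with no visible loss. Phenyl in place of 2,4-dichlorobenzyl gives a 3.0-fold lower number from compound 2 to compound 4 (0.48 log units; beyond the scatter), a step of the same size as removing one chloro alone to reach compound 3. No available evidence explains these results. Still open, as far as these compounds go, is how the number responds to a non-aromatic group on this nitrogen, such as methyl or cyclohexyl, or to an amine on the phenyl ring.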